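This account rests on a few compounds, and the source may have more. Where it says the series, first, only, none or still open, it means among the compounds named here.

Two compounds of the series have numbers in a functional assay on HCT-116 cells (Homo sapiens) for cytotoxicity, read by MTT assay, with a stated time of 72 h (a higher number here means a weaker inhibitor, a lower number a stronger inhibitor), so far. Compound 1 `Cc1cc(-c2ccccc2)n(/C(N)=N/S(=O)(=O)c2cc(C)c(Cl)cc2SCc2ccccc2C(F)(F)F)n1` gives 25000 nM. Compound 2 `Cc1cccc(CSc2cc(Cl)c(C)cc2S(=O)(=O)/N=C(\N)n2nccc2-c2ccccc2)c1` gives 6500 nM, the lower of the two numbers; its gap to compound 1 lies beyond the scatter. Compound 3 `Cc1cc(S(=O)(=O)/N=C(\N)n2nccc2-c2ccccc2)c(SCc2cccc3ccccc23)cc1Cl` is the next member, still without a measurement. It differs from compound 2 in one place: naphthalen-1-yl in place of 3-methylphenyl on a saturated chain carbon bound to a sulfur. Among the measured compounds shown here, no measured pair shows a comparable change, so the step is expected to stay within the scatter, with no clear direction: a 1.3-fold lower number from compound 2 to compound 3 (0.11 log units; within the scatter). For compound 3 in this assay the estimate is 5000 nM, with a range from 1500 nM to 20000 nM.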

Compound 3, half-maximal inhibitory concentration: 7000 nM
Estimate against measurement, compound 3: 1.4-fold (0.15 log units) below; the range from low to high includes it.
By their numbers in this assay, from the lowest: compounds 2 and 3 (each within the scatter of the next); then compound 1.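

Naphthalen-1-yl in place of 3-methylphenyl on a saturated chain carbon bound to a sulfur gives, in this assay, a 1.1-fold higher number from compound 2 to compound 3 (0.03 log units; within the scatter) and so no separation of the two compounds. At this place, 2 six-membered aromatic rings of carbon only and 10 heavy atoms give a number that cannot be told apart from that with one such ring and 7 heavy atoms. No measurement offers an explanation for this result. Still open, on these data alone, is whether an amine, a carboxylic acid or a longer chain on that carbon would give a number beyond the scatter of these two.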